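This account rests on a few compounds, and the source may have more. Where it says the series, first, only, none or still open, it means among the compounds named here.

Measured so far in a functional assay on HT-29 cells (Homo sapiens) for cytotoxicity, read by sulforhodamine B assay (a lower number here means a stronger inhibitor of growth, a higher number a weaker inhibitor of growth), for the series
compound 1 `CC1=CC[C@@H]([C@@](C)(O)CCCC(C)(C)NC(=S)N/N=C\c2ccccc2)CC1` gives 9960 nM
compound 2 `CC1=CC[C@@H]([C@@](C)(O)CCCC(C)(C)NC(=S)N/N=C\c2ccc(C)cc2)CC1` gives 10400 nM

Compound 2 stands level with compound 1, since the two values lie within the scatter of each other. The next change leads to compound 3 `CC1=CC[C@@H]([C@@](C)(O)CCCC(C)(C)NC(=S)N/N=C\c2ccc(O)cc2)CC1` and reads hydroxy in place of methyl on an aromatic carbon in the counted difference, hydroxy in place of methyl on an aromatic carbon. Going by the values given here, one measured step bears on this site. It is a 1.0-fold higher number from compound 1 to compound 2 (0.02 log units; within the scatter) and comes from methyl in place of hydrogen on an aromatic carbon. That step lies within the scatter, so the site has not yet shown a response in this assay to the groups tried. Among the compounds with values here, it is weak evidence, as no measured compound carries hydroxy on the aromatic ring. Within the data shown here, with only that step to go on, no shift beyond the scatter is expected. The expected change is a 1.2-fold lower number from compound 2 to compound 3 (0.06 log units; within the scatter) and remains within the scatter. For compound 3 the estimated value is 9000 nM with an expected range of 4000 nM to 18000 nM in this assay when measured.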

Compound 3, concentration for 50% growth inhibition: 8150 nM
Beside the measured number, compound 3's estimate is 1.1-fold (0.04 log units) above it, within the range that was stated.
By their numbers in this assay, from the lowest: compounds 3, 1 and 2 (each within the scatter of the next).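

In this assay, replacing methyl with hydroxy on the aromatic carbon para to a large group gives a 1.3-fold lower number from compound 2 to compound 3 (0.11 log units; within the scatter) and replacing hydrogen with hydroxy at that carbon gives a 1.2-fold lower number from compound 1 to compound 3 (0.09 log units; within the scatter) for this position. Going by these compounds alone, the first step adds a hydrogen-bond donor and a hydrogen-bond acceptor at a site that had so far carried neither, and this difference in the counts leaves the value within the scatter of the value for the methyl compound. Hydrogen, methyl and hydroxy now form a set of three groups at this carbon whose values all lie within the scatter of one another, and no independent measurement is available to explain this result.

Whether an amine, a carboxylic acid, a nitrile or a longer chain on the same aromatic carbon would move the number beyond the scatter remains open, since the three groups shown are all small and give no response to compare against. On these data alone, all three compounds also share the same core, so the response to a change elsewhere in that core, including the thiocarbonyl group or the tertiary alcohol, also remains open.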